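Swapping the aryl group on a tetrazole amide potassium channel activator

The source may report more compounds than this note shows. Statements on the series, on what has been measured and on what is new or still open speak of the compounds shown alone.

Measured compounds:
- compound 1, `Cc1cc(NC(=O)Cn2nnc(-c3ccccc3)n2)n(C2CCS(=O)(=O)C2)n1`: 1030 nM
- compound 2, `Cc1cc(NC(=O)Cn2nnc(-c3ccc(F)c(F)c3)n2)n(C2CCCCC2)n1`: 116 nM

Both compounds were tested in an assay on HEK293 cells for activation of Kir3.1/Kir3.2 (Homo sapiens), read by thallium flux; on this read-out lower numbers stand for an effect already at smaller amounts and higher numbers for an effect only at larger amounts of compound. Compound 2 gives 116 nM, and of the two numbers shown this is the lowest. Going by the values given here, its only neighbour is compound 1, which differs from it in more than one place. Compound 1 gives 1030 nM, a clearly higher number that lies beyond the usual scatter of this assay. Because the two compounds differ in more than one place, the gap between them cannot be attributed to a single structural change.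

Compound 3, `Cc1cc(NC(=O)Cn2nnc(-c3cccc(C#N)c3)n2)n(C2CCCCC2)n1`, has not yet been measured. It differs from compound 2 in one place only: 3-cyanophenyl in place of 3,4-difluorophenyl on an aromatic carbon. The group that leaves has two fluorine atoms; the group that enters carries one nitrogen in a triple bond outside the aromatic ring and adds one hydrogen-bond acceptor. Among the compounds with values here, no measured pair in this set isolates such an exchange, so the direction of the step is uncertain. The expected step of a 2.2-fold higher number from compound 2 to compound 3 (0.33 log units; beyond the scatter) is a modest one, most likely a small rise in the number, but it could also fall within the scatter. Compound 3 is therefore estimated at 250 nM, with a range from 60 nM to 1000 nM.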

Compound 3, half-maximal effective concentration: 183 nM
Compound 3: middle estimate off by 1.4-fold (0.14 log units), on the high side; the range from low to high includes it.
By their numbers in this assay, from the lowest: compounds 2 and 3 (each within the scatter of the next); then compound 1.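

With the rest of the molecule kept the same, putting 3-cyanophenyl in place of 3,4-difluorophenyl on the five-membered aromatic ring with 4 nitrogen gives, in this assay, a 1.6-fold higher number from compound 2 to compound 3 (0.20 log units; within the scatter), so the two numbers cannot be told apart. This is the first pair shown that isolates this position, and it indicates that the two fluorine atoms can be exchanged for a nitrile, which brings a triple bond outside the ring and one hydrogen-bond acceptor, without a measurable difference in this read-out. No supporting measurement is available to explain why these two different groups give such similar numbers.

The compounds shown leave open whether this position accepts other replacements as well, such as a methoxy group, an amine or a carboxylic acid in place of the nitrile on the phenyl ring. Also open, going by these compounds, is what a plain phenyl group, carrying neither fluorine nor nitrile, would give with the rest of compound 2 kept unchanged.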